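Amide aryl variation in the thiazole series: compound 4

This account rests on a few compounds, and the source may have more. Where it says the series, first, only, none or still open, it means among the compounds named here.

Measured compounds:
compound 1 `CCOC(=O)c1sc(-c2cccc(NC(=O)c3ccc(F)cc3)c2)nc1Nc1ccc(N2CCN(C)CC2)cc1` — 3.53%
compound 2 `CCOC(=O)c1sc(-c2cccc(NC(=O)c3ccc(C(C)(C)C)cc3)c2)nc1Nc1ccc(N2CCN(C)CC2)cc1` — 21.2%
compound 3 `CCOC(=O)c1sc(-c2cccc(NC(=O)c3cccc(F)c3)c2)nc1Nc1ccc(N2CCN(C)CC2)cc1` — 85.2%

In a functional assay on Ramos cells (Homo sapiens) for antiproliferative activity, read by CCK-8 assay, with a stated time of 72 h, tested at 40 uM (on this read-out lower numbers stand for less inhibition and higher numbers for more inhibition at the one concentration tested (going by the name of the read-out)), compound 3 stands highest of the three, with compound 2 nearest and compound 1 furthest. Both gaps are beyond the scatter: a number 64 percentage points higher from compound 2 to compound 3 (beyond the scatter) and a number 81.7 percentage points higher from compound 1 to compound 3 (beyond the scatter).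

Compound 4 `CCOC(=O)c1sc(-c2cccc(NC(=O)c3ccc(C#N)cc3)c2)nc1Nc1ccc(N2CCN(C)CC2)cc1` differs from compound 3 in one place: 4-cyanophenyl in place of 3-fluorophenyl on a carbonyl carbon.

For the measured compounds named here, two measured steps bear on this change. The step of a number 81.7 percentage points higher from compound 1 to compound 3 (beyond the scatter) is the reverse kind of change, a 4-substituted phenyl on the carbonyl carbon giving way to the 3-fluorophenyl, and it is large. The step of a number 17.7 percentage points higher from compound 1 to compound 2 (beyond the scatter) swaps one substituent for another on the 4-substituted phenyl and is modest. Compound 4 returns to a 4-substituted phenyl, so a large drop in this assay is expected, tempered by the modest variation seen between compound 1 and compound 2. For compound 4 in this assay the expected value is 25%, range 3% to 70%, meaning an expected step of a number 60.2 percentage points lower from compound 3 to compound 4 (beyond the scatter).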

Compound 4, a percentage reported as inhibition, at one concentration (the size of the read-out at that concentration, not a potency): 97.5%
Compound 4: middle estimate off by 72.5 percentage points, on the low side; the measured number lies above the stated range.
By their numbers in this assay, from the lowest: compound 1; then compound 2; then compound 3; then compound 4.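

In this assay, a 4-substituted phenyl on the carbonyl carbon no longer goes with a low number, though compound 1 and compound 2 still stand low: cyano gives a number 94 percentage points higher from compound 1 to compound 4 (beyond the scatter) in place of fluoro and a number 76.3 percentage points higher from compound 2 to compound 4 (beyond the scatter) in place of tert-butyl. The group on that aromatic carbon therefore matters far more than the earlier pair suggested, and 4-cyanophenyl in place of 3-fluorophenyl gives a number 12.3 percentage points higher from compound 3 to compound 4 (beyond the scatter), so high inhibition is not confined to the 3-fluorophenyl amide. No measurement here explains why cyano and fluoro differ so widely on the same phenyl.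

On these data alone, it remains open whether a carboxylic acid, an aminomethyl group or a methoxy group on this phenyl would also give high inhibition. Readings at one concentration also leave the potency of compound 3 and compound 4 unresolved.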